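Shortening the Ether Chain on a Chloroquinoline Core

This account rests on a few compounds, and the source may have more. Where it says the series, first, only, none or still open, it means among the compounds named here.

Of the compounds shown here, two have been tested. Compound 1 `CCCCCCOc1ccc2c(Cl)ccnc2c1` and compound 2 `C=CCOc1ccc2c(NCCCN(C)C)ccnc2c1` share a core but differ in the chain on the aromatic oxygen and in the group on the opposite side. In a functional assay on NCI-H1650 cells (Homo sapiens) for cytotoxicity, read by MTT assay, with a stated time of 48 h (on this read-out lower numbers stand for stronger inhibition and higher numbers for weaker inhibition), compound 1 gives 2080 nM, and compound 2 gives 3120 nM; these two numbers lie within the scatter of each other, so neither can be called stronger.

Compound 3 `CC(C)COc1ccc2c(Cl)ccnc2c1` has not yet been measured. It differs from compound 1 by one change: isopropyl in place of pentyl on a saturated chain carbon bound to an oxygen on an aromatic ring. Among the measured compounds shown here, no step between two measured compounds tells what such a shortening does here, so the expectation rests on compound 1 alone. A step no larger than the scatter, or a modest shift toward a higher number, is expected for a 1.4-fold higher number from compound 1 to compound 3 (0.16 log units; within the scatter). On that basis compound 3 is estimated at 3000 nM, with a range from 1200 nM to 8000 nM.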

Compound 3, half-maximal inhibitory concentration: 2100 nM
Beside the measured number, compound 3's estimate is 1.4-fold (0.15 log units) above it; measured number inside the range.
By their numbers in this assay, from the lowest: compounds 1, 3 and 2 (each within the scatter of the next).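

Placing isopropyl in place of pentyl on a saturated chain carbon bound to an oxygen on an aromatic ring gives, in this assay, a step within the scatter (a 1.0-fold higher number from compound 1 to compound 3 (0.00 log units; within the scatter)). Among the compounds shown here, this is the first step at this position that can be read, and it shows that a group of 3 heavy atoms and one of 5 heavy atoms cannot be told apart here, so this group can be cut down on the shared core without a measurable loss in this cell read-out. Nothing measured here speaks to why the two compounds read alike.

On these data alone, a single step says little about the wider reach of this position, so the effect of a much longer chain, such as decyl, remains open. So does the effect of a phenyl ring, an amine or a carboxylic acid placed on the chain.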